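This account rests on a few compounds, and the source may have more. Where it says the series, first, only, none or still open, it means among the compounds named here.

Compound 1 `CC(C)(C)Nc1nc(=O)c2cc([N+](=O)[O-])cc([N+](=O)[O-])c2s1`: in an ADME assay on Vero cells (Chlorocebus sabaeus) for cytotoxicity, read by MTT assay, with a stated time of 72 h (on this read-out lower numbers stand for stronger inhibition and higher numbers for weaker inhibition), the result for compound 1 is recorded as "not determined" (no result reported).
Compound 2 `CC(C)CNc1nc(=O)c2cc(C(F)(F)F)cc([N+](=O)[O-])c2s1`: in this assay compound 2 reaches only an assay limit, > 100000 nM.

Among the measured compounds shown here, compound 2 therefore stands at the limit of > 100000 nM in this assay, at which 1 of the 2 values shown sits, with no single number beside it and no measured step to another compound. Compound 3 `O=C(O)C1CCN(c2nc(=O)c3cc(C(F)(F)F)cc([N+](=O)[O-])c3s2)CC1` differs from compound 2 by 4-carboxypiperidin-1-yl in place of isobutylamino on an aromatic carbon. Without any measured step to lean on, no shift beyond the scatter is expected in this assay, which means a number no higher from compound 2 to compound 3 (the limit leaves the size open). Compound 3 is thus estimated at 100000 nM, within 30000 nM to 300000 nM, most likely again reported only as a limit.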

Compound 3, half-maximal inhibitory concentration: > 100000 nM
Compound 3: only a limit was reported; the forecaster's own chance of this, stated with the estimate: 85%; the middle value sits exactly at the limit.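

No step can be read between compound 2 and compound 3 in this assay, as each reaches only an assay limit. As far as these compounds go, whether 4-carboxypiperidin-1-yl in place of isobutylamino shifts this read-out at all remains open.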